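A few compounds are considered here, and "the series" means these few. Any claim that something is new, unique, unknown or untested is made for them only; others in the source may bear on it.

The three measured compounds share one core and differ only in one halogen. In an assay on HEK293 cells for displacement of a labelled ligand from metabotropic glutamate receptor 5 (Rattus norvegicus) (on this read-out higher numbers stand for weaker inhibition and lower numbers for stronger inhibition), compound 1 `O=C(Nc1cc(-c2ccccc2)nn1-c1ccccc1F)c1ccccc1` gives 2700 nM, compound 2 `O=C(Nc1cc(-c2ccccc2)nn1-c1ccccc1Cl)c1ccccc1` gives 500 nM, and compound 3 `O=C(Nc1cc(-c2ccccc2)nn1-c1ccccc1Br)c1ccccc1` gives 2600 nM. Compound 3 thus stands second highest of the three numbers, lying within the scatter of compound 1 and well apart from compound 2, as a 5.2-fold higher number from compound 2 to compound 3 (0.72 log units; beyond the scatter) shows. Compound 4 `O=C(Nc1cc(-c2ccccc2)nn1-c1ccccn1)c1ccccc1` carries pyridin-2-yl in place of 2-bromophenyl on an aromatic nitrogen. Among the compounds with values here, none of the measured steps exchanges a halogenated ring for a heteroaryl ring: a 5.4-fold lower number from compound 1 to compound 2 (0.73 log units; beyond the scatter) and a 1.0-fold lower number from compound 1 to compound 3 (0.02 log units; within the scatter) are halogen swaps only. Within the data shown here, no step bears directly on this change, so the step is expected to stay within the scatter: a 1.0-fold lower number from compound 3 to compound 4 (0.02 log units; within the scatter). Compound 4 is therefore estimated at 2500 nM, ranging from 600 nM to 10000 nM.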

Compound 4, inhibition constant: > 10000 nM
Compound 4: only a limit was reported (the forecaster's own chance of this, stated with the estimate: 10%); middle value at least 4.0-fold (0.60 log units) away from the limit.
By their numbers in this assay, from the lowest: compound 2; then compounds 3 and 1 (each within the scatter of the next). At a limit, above all of these: compound 4.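

Compound 4 gives no number but a limit: the limit of > 10000 nM in this assay, at which 1 of the 4 values shown sits. In this assay, exchanging the whole ring on the aromatic nitrogen, rather than only its halogen, gives an at least 3.8-fold higher number from compound 3 to compound 4 (0.58 log units; beyond the scatter) and an at least 3.7-fold higher number from compound 1 to compound 4 (0.56 log units; beyond the scatter) and an at least 20-fold higher number from compound 2 to compound 4 (1.30 log units; beyond the scatter) with all three steps beyond the scatter. Compound 4 thus shows the weakest inhibition of the four, so this position responds to the ring itself as well as to the halogen.

The compounds shown do not separate the ring nitrogen from the missing halogen. A plain phenyl or a chloro-substituted pyridine here would tell these apart.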